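Dropping a Methylamino Group and Its Expected Exposure

The source may report more compounds than this note shows. Statements on the series, on what has been measured and on what is new or still open speak of the compounds shown alone.

Compound 2 `CNc1cc(-n2nc(C(C)C)c3c(-n4cnc(-c5cnn(C)c5)c4)ccnc32)ccc1C(N)=O` carries a methylamino group and a carbamoyl group on the same six-membered ring. In an ADME assay on the whole organism (Mus musculus, strain Balb/cA) for pharmacokinetics, read by LC-MS, with a stated time of 6 h, at a dose of 50 mg/kg by the oral route (a higher number here means more compound in the circulation at the dose given, a lower number less compound in the circulation), compound 2 gives "not determined" (no result reported), so no number for it is known. Among the measured compounds shown here, a close relative, compound 1 `CNc1cc(C(N)=O)ccc1-n1nc(C(C)C)c2c(-n3cnc(-c4cnn(C)c4)c3)ccnc21`, which carries the same groups in a different arrangement, gives 1230 ng.h/mL in this assay, the only measured value here. Compound 3 `CC(C)c1nn(-c2ccc(C(N)=O)cc2)c2nccc(-n3cnc(-c4cnn(C)c4)c3)c12` is compound 2 with the methylamino group removed: hydrogen in place of methylamino on an aromatic carbon. For the measured compounds named here, no measured pair with this same change exists, so the size of the step in this assay is an open question; with one small group leaving and nothing entering, the step could plausibly stay within the scatter or shift the value modestly in either direction. Compound 3 is expected to give about 1000 ng.h/mL in this assay, within a range from 300 ng.h/mL to 3500 ng.h/mL.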

Compound 3, area under the concentration-time curve in the Mus musculus assay: 2130 ng.h/mL
Compound 3: the middle estimate sits 2.1-fold (0.33 log units) below what was measured, and the stated range covers the measured number.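

In the Mus musculus assay, replacing the methylamino group with hydrogen gives a 1.7-fold higher number from compound 1 to compound 3 (0.24 log units; within the scatter), so at this dose compound 3 shows exposure that cannot be told apart from that of compound 1. In a physicochemical assay for solubility, at pH 7.4 (a higher number here means a more soluble compound, a lower number a less soluble compound), compound 2 gives < 2000 nM, a limit of the assay and not a number, which makes any step from it a floor only: the limit of < 2000 nM in the physicochemical assay, at which 1 of the 2 values shown sits. In the physicochemical assay compound 3 gives 4000 nM, and the step reads an at least 2.0-fold higher number from compound 2 to compound 3 (0.30 log units; that floor lies within the scatter).

On these data alone, the step from compound 2 to compound 3 in the Mus musculus assay cannot be read, so the effect of this change with the rest of the arrangement held fixed stays open. Also open, as far as these compounds go, is how a methoxy group or a fluorine atom would behave at this place, ortho to a carbamoyl group.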